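A few compounds are considered here, and "the series" means these few. Any claim that something is new, unique, unknown or untested is made for them only; others in the source may bear on it.

Measured so far:
- Compound 1 `COC1Cc2sccc2C2(CCN(CCC(C)C)CC2)O1`: 1 nM
- Compound 2 `COC1Cc2sccc2C2(CCN(CCCCc3ccccc3)CC2)O1`: 7.7 nM

Both were tested in an assay on membranes from brain for displacement of a labelled ligand from Sigma non-opioid intracellular receptor 1 (Cavia porcellus); on this read-out higher numbers stand for weaker inhibition and lower numbers for stronger inhibition. Compound 1 gives the lower of the two numbers, and compound 2, which carries phenethyl in place of isopropyl on a saturated chain carbon, two bonds along the chain from an amine nitrogen in a ring, sits a 7.7-fold higher number from compound 1 to compound 2 (0.89 log units; beyond the scatter).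

Compound 3 `CCCCCN1CCC2(CC1)OC(OC)Cc1sccc12` has not yet been measured. It differs from compound 1 only in the chain on that amine: propyl in place of isopropyl on a saturated chain carbon, two bonds along the chain from an amine nitrogen in a ring. The two compounds share every atom and differ just in how the three-carbon chain is joined.

Among the compounds with values here, only one measured step touches this position, and it is a larger change than the one at hand: swapping isopropyl for phenethyl moved the number by a 7.7-fold higher number from compound 1 to compound 2 (0.89 log units; beyond the scatter). Straightening isopropyl into propyl is a far smaller alteration, and nothing among the measured compounds shows what that alone does. The expectation for compound 3 is therefore a step of about a 1.5-fold higher number from compound 1 to compound 3 (0.18 log units; within the scatter), which would stay within the usual scatter, with compound 3 estimated at 1.5 nM, plausibly between 0.5 nM and 4.5 nM.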

Compound 3, inhibition constant: 1.6 nM
The estimate for compound 3 lay 1.1-fold (0.03 log units) below the measured number, within the range that was stated.
By their numbers in this assay, from the lowest: compounds 1 and 3 (each within the scatter of the next); then compound 2.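

In this assay, propyl in place of isopropyl on a saturated chain carbon, two bonds along the chain from an amine nitrogen in a ring, gives a 1.6-fold higher number from compound 1 to compound 3 (0.20 log units; within the scatter) and so leaves compounds 1 and 3 indistinguishable; in this pair, whether the chain end is branched or straight makes no difference that can be told from the scatter. The other new step, methyl in place of phenyl on a saturated chain carbon, four bonds along the chain from an amine nitrogen in a ring, gives a 4.8-fold lower number from compound 2 to compound 3 (0.68 log units; beyond the scatter), which lies beyond the scatter, so compound 2 with its phenyl-ended chain now stands apart from both compounds with all-carbon open chains. No measurement shown here explains these results.

As far as these compounds go, it remains open whether a cyclohexyl at the end of the chain would match the phenyl of compound 2 or the methyl of compound 3, which would show whether any ring there gives the same result. A hydroxyl or an amine at the chain end, or a longer chain such as decyl, could also show how much this position tolerates beyond simple carbon chains.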